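This account rests on a few compounds, and the source may have more. Where it says the series, first, only, none or still open, it means among the compounds named here.

Measured so far in an ADME assay on microsomes from liver (Mus musculus) for metabolic stability, with a stated time of 10 min; on this read-out lower numbers stand for a less stable compound and higher numbers for a more stable compound
- compound 1 `C[C@]1(C(=O)O)CC[C@H](C(=O)N2CC[C@](c3ccc(C(F)(C(F)(F)F)C(F)(F)F)cc3)(S(=O)(=O)c3ccc(F)cc3)C2)CC1` with 93%
- compound 2 `O=C([C@H]1CC[C@H](c2nnn[nH]2)CC1)N1CC[C@](c2ccc(C(F)(C(F)(F)F)C(F)(F)F)cc2)(S(=O)(=O)c2ccc(F)cc2)C1` with 73%

Of these two, compound 2 stands lower, at 73% in this read-out. Compound 3 `O=C(C1CCS(=O)(=O)CC1)N1CC[C@](c2ccc(C(F)(C(F)(F)F)C(F)(F)F)cc2)(S(=O)(=O)c2ccc(F)cc2)C1` keeps the shared core and changes one group: 1,1-dioxothian-4-yl in place of 4-(1H-tetrazol-5-yl)cyclohexyl on a carbonyl carbon. Among the measured compounds shown here, only one measured step touches this place, a number 20 percentage points lower from compound 1 to compound 2 (beyond the scatter) in this assay, and it shows that a swap here can move the number by a modest amount. That step does not include the entering group, so it offers a rough size but no direction. The expected change is therefore small, a number 5 percentage points higher from compound 2 to compound 3 (within the scatter) as an estimate, with no clear step beyond the scatter foreseen. Compound 3 is expected at 78% (estimated range 55% to 95%).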

Compound 3, percent of the compound remaining: 96%
The estimate for compound 3 lay 18 percentage points below the measured number; the measured number lies above the stated range.
By their numbers in this assay, from the lowest: compound 2; then compounds 1 and 3 (each within the scatter of the next).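

In this assay, replacing the 4-(1H-tetrazol-5-yl)cyclohexyl group with 1,1-dioxothian-4-yl gives a number 23 percentage points higher from compound 2 to compound 3 (beyond the scatter) and shows that the number can rise again at this place on the carbonyl carbon. The comparison with the carboxylic acid-bearing group gives a number 3 percentage points higher from compound 1 to compound 3 (within the scatter) and so does not tell 1,1-dioxothian-4-yl and 4-carboxy-4-methylcyclohexyl apart in this read-out. No supporting measurement is available to explain why the tetrazole-bearing group stands apart from these two.

These compounds leave open whether a cyclohexyl ring carrying an amine, or a longer open chain, would give a number like that of compound 3. They also do not separate the tetrazole ring from the cyclohexyl ring that carries it, as the two leave together.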